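Ester Series on Colon Cancer Cells: Moving the Methoxy Group

The compounds below may be only part of what the source reports. "The series", "measured", "known", "first", "only" and "open" are said of these compounds alone.

Measured compounds:
compound 1 `COc1ccc(-c2cn(-c3ccc(O)c(C(=O)O)c3)nn2)cc1` with 8%
compound 2 `COc1cc(OC)cc(-c2cn(-c3ccc(O)c(C(=O)OCCCc4ccccc4)c3)nn2)c1` with 19%
compound 3 `COc1ccccc1-c1cn(-c2ccc(O)c(C(=O)OCCCc3ccccc3)c2)nn1` with 7%

In a functional assay on HCT-116 cells (Homo sapiens) for inhibition, read by MTT assay, with a stated time of 2 days, tested at 10 uM (a higher number here means more inhibition at the concentration tested (going by the name of the read-out), a lower number less inhibition), compound 3 gives the lowest of the three numbers. Its nearest neighbour is compound 1, and the gap between the two lies within the scatter, so nothing separates them. Going by the values given here, compound 2 sits furthest away, and the one step that joins it to compound 3 is a number 12 percentage points lower from compound 2 to compound 3 (beyond the scatter), a modest fall.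

Compound 4 `COc1ccc(-c2cn(-c3ccc(O)c(C(=O)OCCCc4ccccc4)c3)nn2)cc1` has not been measured. It differs from compound 3 in one place: 4-methoxyphenyl in place of 2-methoxyphenyl on an aromatic carbon. Among the compounds with values here, no measured pair shows exactly this change. Within the data shown here, the only step available, a number 12 percentage points lower from compound 2 to compound 3 (beyond the scatter), concerns a different methoxyphenyl exchange and is modest in size. Compound 1, which carries the 4-methoxyphenyl but lacks the ester, gives 8%, a low figure. The numbers therefore give no reason to expect anything beyond the scatter in this assay for compound 4, with at most a small rise. Compound 4 is expected to give about 10%, in the range 0% to 24%. That estimate means a step of a number 3 percentage points higher from compound 3 to compound 4 (within the scatter), which is expected to remain within the scatter.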

Compound 4, a percentage reported as inhibition, at one concentration (the size of the read-out at that concentration, not a potency): 12%
The estimate for compound 4 lay 2 percentage points below the measured number; low and high end bracket the measured number.
By their numbers in this assay, from the lowest: compounds 3, 1, 4 and 2 (each within the scatter of the next, the first and the last beyond it).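

In this assay, exchanging 2-methoxyphenyl for 4-methoxyphenyl on this aromatic carbon of the five-membered ring, with the same atoms joined differently, gives a number 5 percentage points higher from compound 3 to compound 4 (within the scatter), so the data do not separate these two groups. With 3,5-dimethoxyphenyl as the reference, the 4-methoxyphenyl step is a number 7 percentage points lower from compound 2 to compound 4 (within the scatter), while the 2-methoxyphenyl step is a number 12 percentage points lower from compound 2 to compound 3 (beyond the scatter), so the fall seen earlier is not reproduced beyond the scatter by the second single-methoxy group. Going by these compounds alone, the result also gives the first direct reading of the ester with the aryl group held constant: 3-phenylpropyl in place of hydrogen on the oxygen next to the carbonyl gives a number 4 percentage points higher from compound 1 to compound 4 (within the scatter), which shows no separation between the ester and its parent acid at this single concentration.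

No supporting data bear on why these numbers fall as they do. The compounds shown leave open whether a 3-methoxyphenyl or a 3,4,5-trimethoxyphenyl on this carbon, or an amide or a longer chain in place of the 3-phenylpropyl ester, would lift the number beyond the scatter.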